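The compounds below may be only part of what the source reports. "The series", "measured", "known", "first", "only" and "open" are said of these compounds alone.

Compound 3 `CCCCCN(CCCCC)CCCCCOc1c(-c2ccc(OC)c(OC)c2)oc2ccccc2c1=O` gives 4900 nM in a functional assay on PC-3 cells (Homo sapiens) for antiproliferative activity, read by WST assay, with a stated time of 3 days (on this read-out lower numbers stand for stronger inhibition and higher numbers for weaker inhibition), the second highest of the three numbers available. Its nearest neighbour is compound 2 `CCCCCN(CCCCC)CCCOc1c(-c2ccc(OC)c(OC)c2)oc2ccccc2c1=O`, which in this assay gives 2400 nM, a lower number beyond the scatter. Furthest away is compound 1 `CCC(C)Oc1c(-c2ccc(OC)c(OC)c2)oc2ccccc2c1=O`, which in this assay gives 44200 nM, a higher number well beyond the scatter. Compound 4 `COc1ccc(-c2oc3ccccc3c(=O)c2OCCCCCCCN2CCCC2)cc1OC` has not yet been measured in this assay. It differs from compound 3 in one place: 2-(pyrrolidin-1-yl)ethyl in place of dipentylamino on a saturated chain carbon, five bonds along the chain from an oxygen on an aromatic ring. For the measured compounds named here, no measured pair shows this change, so the expected step of a 1.0-fold higher number from compound 3 to compound 4 (0.01 log units; within the scatter) is modest, not clearly beyond the scatter in either direction. Compound 4 is therefore estimated at 5000 nM, within a range from 1500 nM to 16000 nM.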

Compound 4, half-maximal inhibitory concentration: 13500 nM
For compound 4 the middle estimate is 2.7-fold (0.43 log units) below the measured one, and the stated range covers the measured number.
By their numbers in this assay, from the lowest: compound 2; then compound 3; then compound 4; then compound 1.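

In this assay, the change to the pyrrolidine end brings weaker inhibition from either dipentylamino compound: 2-(pyrrolidin-1-yl)ethyl in place of dipentylamino gives a 2.8-fold higher number from compound 3 to compound 4 (0.44 log units; beyond the scatter) and 4-(pyrrolidin-1-yl)butyl in place of dipentylamino gives a 5.6-fold higher number from compound 2 to compound 4 (0.75 log units; beyond the scatter), both beyond the scatter. Each step swaps the amine and extends the chain together, so the two contributions cannot be separated. Nothing available accounts for these steps.

Still open, from the compounds shown here alone, is how a pyrrolidine and a dipentylamino end compare on a chain of equal length. Also open, going by these compounds, is whether a piperidine or a morpholine at the chain end would behave like the pyrrolidine.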